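A few compounds are considered here, and "the series" means these few. Any claim that something is new, unique, unknown or untested is made for them only; others in the source may bear on it.

In an assay on HEK293 cells for inhibition of Steryl-sulfatase (Homo sapiens), tested at 1 uM (on this read-out lower numbers stand for a weaker effect and higher numbers for a stronger effect at the one concentration tested), compound 2 `CCCN(CCC)c1ccc(C(=O)N2CCc3ccc(OS(N)(=O)=O)cc3C2)cc1` gives 84.7%, and compound 1 `CN(CCN1CCCCC1)c1ccc(C(=O)N2CCc3ccc(OS(N)(=O)=O)cc3C2)cc1` gives 26.8%. Between them stands the change (methyl(2-(piperidin-1-yl)ethyl)amino in place of dipropylamino on an aromatic carbon), which made a number 57.9 percentage points lower from compound 2 to compound 1 (beyond the scatter). Compound 3 `CCCN(CCC)c1cccc(C(=O)N2CCc3ccc(OS(N)(=O)=O)cc3C2)c1` gives 54.8% in this assay; how its core differs from that of compound 2 is not broken down here. Compound 4 `CN(CCN1CCCCC1)c1cccc(C(=O)N2CCc3ccc(OS(N)(=O)=O)cc3C2)c1`, not yet measured, differs from compound 3 by methyl(2-(piperidin-1-yl)ethyl)amino in place of dipropylamino on an aromatic carbon, the same kind of change as from compound 2 to compound 1, though the place is not the same: there the entering group stood para to a large group, here meta to a large group. Because compound 1 fell to 26.8%, compound 4 is expected to show a downward step of a number 36.8 percentage points lower from compound 3 to compound 4 (beyond the scatter), smaller in size since compound 3 starts lower. Compound 4 is thus estimated at 18%, between 2% and 42%.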

Compound 4, a percentage reported as inhibition, at one concentration (the size of the read-out at that concentration, not a potency): 30.8%
Compound 4: the middle estimate sits 12.8 percentage points below what was measured; low and high end bracket the measured number.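

Putting methyl(2-(piperidin-1-yl)ethyl)amino in place of dipropylamino again lowered the read-out in this assay, with a number 24 percentage points lower from compound 3 to compound 4 (beyond the scatter) on this second core. The direction of the change therefore carried over from one core to the other, but its size did not: the same change on two cores in this assay, a number 57.9 percentage points lower (beyond the scatter) from compound 2 to compound 1 and a number 24 percentage points lower (beyond the scatter) from compound 3 to compound 4, 33.9 percentage points apart, beyond the scatter of two such steps. Among these compounds, two pairs show only that the core matters to the size of the step; they give no rule for a further core and do not explain the gap.

From the compounds shown here alone, it remains open whether a morpholine ring in place of the piperidine ring, or a longer chain leading to that ring, would lower the read-out as far. Going by these compounds, how a simple dimethylamino group would read on either core is also open.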